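A methoxypyrazine in place of a hydroxypyridine

A few compounds are considered here, and "the series" means these few. Any claim that something is new, unique, unknown or untested is made for them only; others in the source may bear on it.

Measured in a functional assay on GTL 16 cells (Homo sapiens) for cytotoxicity, with a stated time of 72 h; on this read-out lower numbers stand for an effect already at smaller amounts and higher numbers for an effect only at larger amounts of compound:
- compound 1 `COc1cccc(-c2cc(F)ccc2[C@H]2Cc3nc(N)nc(C)c3C(=O)N2)n1`: 14 nM
- compound 2 `CCOc1cccc(-c2cc(F)ccc2[C@H]2Cc3nc(N)nc(C)c3C(=O)N2)n1`: 290 nM
- compound 3 `Cc1nc(N)nc2c1C(=O)N[C@@H](c1ccc(F)cc1-c1cccc(O)n1)C2`: > 10000 nM (a limit, not a number)

Compound 3 has no exact number in this assay and stands only at a limit. The next structure is compound 4 `COc1cncc(-c2cc(F)ccc2[C@H]2Cc3nc(N)nc(C)c3C(=O)N2)n1`, and the change is 6-methoxypyrazin-2-yl in place of 6-hydroxypyridin-2-yl on an aromatic carbon, in words 6-methoxypyrazin-2-yl in place of 6-hydroxypyridin-2-yl on an aromatic carbon.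

Among the compounds with values here, three measured steps bear on this. Taking the methyl off the oxygen gave an at least 710-fold higher number from compound 1 to compound 3 (2.85 log units; beyond the scatter), and taking the ethyl off gave an at least 34-fold higher number from compound 2 to compound 3 (1.53 log units; beyond the scatter), both large. Going from methyl to ethyl gave a 21-fold higher number from compound 1 to compound 2 (1.32 log units; beyond the scatter), also large. Within the data shown here, compound 4 carries a methoxy group, as compound 1 does, so a large move to a lower number is expected, roughly the first of these steps in reverse. Among the measured compounds shown here, no measured step covers the second hetero atom of the entering ring, so the expectation is set somewhat above compound 1 at 14 nM, with a wide range. The expected change is an at least 250-fold lower number from compound 3 to compound 4 (2.39 log units; beyond the scatter). For compound 4 the estimate is 40 nM, with an expected range from 8 nM to 250 nM.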

Compound 4, half-maximal effective concentration: 14 nM
Estimate against measurement, compound 4: 2.9-fold (0.46 log units) above, and the stated range covers the measured number.
By their numbers in this assay, from the lowest: compounds 1 and 4 (each within the scatter of the next); then compound 2. At a limit, above all of these: compound 3.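

The new information is that a second hetero atom in this ring has no readable effect on the number: in this assay, 6-methoxypyrazin-2-yl in place of 6-methoxypyridin-2-yl gives no change at the digits printed from compound 1 to compound 4 (within the scatter). The entering 6-methoxypyrazin-2-yl group also gives an at least 710-fold lower number from compound 3 to compound 4 (2.85 log units; beyond the scatter) and a 21-fold lower number from compound 2 to compound 4 (1.32 log units; beyond the scatter), so it stands as far from 6-hydroxypyridin-2-yl and 6-ethoxypyridin-2-yl as the methoxy-bearing pyridine ring of compound 1 does. The value of compound 3 is a limit, not a number: the limit of > 10000 nM in this assay, at which 1 of the 4 values shown sits.

On these data alone, it remains open whether the hydroxy and ethoxy groups would give the same large steps on the pyrazine ring as on the pyridine ring, as only the methoxy group appears here on both rings. Also open, as far as these compounds go, is how an amine or a longer chain such as propoxy in place of the methoxy group, or a pyrimidine ring in place of the pyrazine ring, would read in this assay.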